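Methylating the Amine of a Diarylmethane Dopamine Transporter Inhibitor

The source may report more compounds than this note shows. Statements on the series, on what has been measured and on what is new or still open speak of the compounds shown alone.

Measured compounds:
compound 1 `CC(c1ccc(Cl)c(Cl)c1)c1ccccc1CN(C)C`, an assay on HEK293 cells for inhibition of sodium-dependent dopamine transporter (Homo sapiens); a lower number here means a stronger inhibitor, a higher number a weaker inhibitor: "not determined" (no result reported)
compound 2 `CNCc1ccccc1Cc1ccc(SC)cc1`, this assay: 5900 nM

Compound 2 holds the only numerical result in this series; in this assay compound 2 gives 5900 nM, while compound 1 is recorded as "not determined" (no result reported). Compound 3 `CSc1ccc(Cc2ccccc2CN(C)C)cc1` differs from compound 2 in one place: methyl in place of hydrogen on an amine nitrogen. Going by the values given here, no pair of measured compounds shows this change, so its effect has to be judged without a measured step. A single methyl added to an amine nitrogen of this kind is, in general, a small change, and the expectation is a step no larger than the usual scatter, with a slight lean toward weaker inhibition. The step from compound 2 to compound 3 is therefore expected to be a 1.3-fold higher number from compound 2 to compound 3 (0.10 log units; within the scatter). For compound 3 the estimated value in this assay is 7500 nM, with a range from 2500 nM to 22000 nM.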

Compound 3, half-maximal inhibitory concentration: 11000 nM
Compound 3: the middle estimate sits 1.5-fold (0.17 log units) below what was measured, within the range that was stated.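

In this assay, the methylamino to dimethylamino change gives a 1.9-fold higher number from compound 2 to compound 3 (0.27 log units; within the scatter) and stays within the usual scatter. Going by these compounds alone, this is the first step read at this amine nitrogen, and it shows that methyl can stand in place of hydrogen here without a change that can be told from repeated measurement. With one pair on one core, this holds only for the step between these two compounds, and nothing at hand explains its size.

Going by these compounds, whether a larger group on this nitrogen, such as ethyl or isopropyl, or an unsubstituted primary amine would also leave the reading within the scatter remains open. Also open, on these data alone, is whether the same methyl step would hold on the core of compound 1, which carries dimethylamino but has no number here.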